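Shortening 3-chloropropyl to 2-hydroxyethyl in a weak series

The compounds below may be only part of what the source reports. "The series", "measured", "known", "first", "only" and "open" are said of these compounds alone.

Compound 2 `O=c1cc(Cn2cc(CCCCl)nn2)c2ccc(O)cc2o1` was tested in a functional assay on CFPAC-1 cells (Homo sapiens) for inhibition, read by MTT assay, with a stated time of 72 h (a higher number here means a weaker inhibitor, a lower number a stronger inhibitor), where compound 2 gives 75800 nM. Going by the values given here, that is the only number in this small set. Compound 1 `O=c1cc(Cn2cc(C3CC3)nn2)c2ccc(O)cc2o1` returned only a limit: in this assay compound 1 gives > 100000 nM. The step of an at least 1.3-fold lower number from compound 1 to compound 2 (0.12 log units; that floor lies within the scatter) can therefore not be sized beyond its floor, and the limit of > 100000 nM in this assay, at which 1 of the 2 values shown sits, is all the limit conveys. Compound 3 `O=c1cc(Cn2cc(CCO)nn2)c2ccc(O)cc2o1` differs from compound 2 by hydroxy in place of chloromethyl on a saturated chain carbon, two bonds along the chain from an aromatic carbon. Among the compounds with values here, only the step from compound 1 to compound 2 has been measured; it touches the same chain end and was small, and nothing measured bears on a hydroxy group at this place. Any change in this assay for compound 3 is thus uncertain in direction and size, and the estimate for compound 3 amounts to the step of a 1.3-fold higher number from compound 2 to compound 3 (0.12 log units; within the scatter), which is expected to stay within the scatter. On that basis compound 3 is estimated at 100000 nM, between 40000 nM and 300000 nM, with a fair chance that only a limit is reported.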

Compound 3, half-maximal inhibitory concentration: > 100000 nM
Compound 3: only a limit was reported; the forecaster's own chance of this, stated with the estimate: 45%; the middle value lies on the limit itself.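

In this assay, as far as these compounds go, hydroxy in place of chloromethyl on a saturated chain carbon, two bonds along the chain from an aromatic carbon, gives an at least 1.3-fold higher number from compound 2 to compound 3 (0.12 log units; that floor lies within the scatter), so the shorter 2-hydroxyethyl chain shows no sign of a gain over the 3-chloropropyl chain, though the true size of the step stays unknown and its floor lies within the scatter. Going by these compounds alone, compound 3 gives only a limit, as compound 1 does, which leaves compound 2 as the one compound in the set with a number and gives the series no second number to compare it with: the limit of > 100000 nM in this assay, at which 2 of the 3 values shown sit. The step between compound 1 and compound 3 cannot be read, as both of its ends are limits.

This change shortens the chain and replaces the chlorine with hydroxy in one move, so a 3-hydroxypropyl chain would be needed to tell the two apart. From the compounds shown here alone, whether an amine or a carboxylic acid at the chain end, or a longer chain, would give a number clearly lower than that of compound 2 stays open.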